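The source may report more compounds than this note shows. Statements on the series, on what has been measured and on what is new or still open speak of the compounds shown alone.

Compound 1 `C=C1CC[C@@H]2[C@](C)(CO)[C@H](O)CC[C@@]2(C)[C@@H]1CCC1C(=O)OC[C@H]1O` gives 34.2% in an assay on isolated protein for inhibition of Maltase-glucoamylase (Homo sapiens), tested at 100 uM; a higher number here means more inhibition at the concentration tested (going by the name of the read-out), a lower number less inhibition. Compound 2 `C=C1CC[C@@H]2[C@](C)(CO)[C@H](O)CC[C@@]2(C)[C@@H]1/C=C/C1=C/C(=C/C)OC1=O` gives 15.1% in this assay, the lowest of the three numbers, with compound 1 beyond the scatter above it. Compound 3 `C=C1CC[C@@H]2[C@](C)(CO)[C@H](O)CC[C@@]2(C)[C@@H]1/C=C/C1=CC(=C(C)C)OC1=O` gives 17.1% in this assay. The step of a number 2 percentage points higher from compound 2 to compound 3 (within the scatter) replaces one five-membered side group by a slightly larger one and leaves the read-out within the scatter.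

Compound 4 `C=C1CC[C@@H]2[C@](C)(CO)[C@H](O)CC[C@@]2(C)[C@@H]1/C=C/C1=C/C(=C/CCC)OC1=O` differs from compound 2 by ethyl in place of hydrogen on a saturated chain carbon bound to a double-bonded chain carbon. Within the data shown here, the only measured step that alters the same part of the structure is the one from compound 2 to compound 3, and it stayed within the scatter. No step beyond the scatter is therefore expected in this assay for compound 4. Compound 4 is estimated at 17%, with a range from 5% to 30%. The expected step is a number 1.9 percentage points higher from compound 2 to compound 4 (within the scatter).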

Compound 4, a percentage reported as inhibition, at one concentration (the size of the read-out at that concentration, not a potency): 43.5%
Estimate against measurement, compound 4: 26.5 percentage points below, outside the stated range (above it).
By their numbers in this assay, from the lowest: compounds 2 and 3 (each within the scatter of the next); then compounds 1 and 4 (each within the scatter of the next).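

In this assay, ethyl in place of hydrogen on a saturated chain carbon bound to a double-bonded chain carbon gives a number 28.4 percentage points higher from compound 2 to compound 4 (beyond the scatter) and so shows that the read-out responds to a change at this position. The earlier step of a number 2 percentage points higher from compound 2 to compound 3 (within the scatter) altered the same part of the structure without showing any such response, so added carbon alone does not account for a rise across these compounds. Nothing available explains the size of the new step.

Still open, on these data alone, is whether a longer chain than propyl takes the number further, or whether it falls back. Also open, as far as these compounds go, is how a hydroxyl or an amine on this chain would read.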